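Replacing the aryl tail of compound 1 by cyclohexyl

The compounds below may be only part of what the source reports. "The series", "measured", "known", "first", "only" and "open" are said of these compounds alone.

Measured in a functional assay on membranes from Sf9 cells for agonist activity at histamine H2 receptor (Homo sapiens), read by scintillation counting and GTPgammaS binding, with a stated time of 90 min; a lower number here means that less compound is needed, a higher number that more compound is needed for the effect:
compound 1, `Cc1ccc(CC(C)CNC(=O)/N=C(\N)NCCCc2sc(N)nc2C)cc1`, gives 60.3 nM
compound 2, `CCCCCCNC(=O)/N=C(\N)NCCCc1sc(N)nc1C`, gives 38.9 nM
compound 3, `Cc1nc(N)sc1CCCN/C(N)=N/C(=O)NCc1ccccc1`, gives 28.8 nM

Compound 1 has the highest of the three numbers; its gap to compound 2 is within the scatter, its gap to compound 3 beyond it. Compound 4, `Cc1nc(N)sc1CCCN/C(N)=N/C(=O)NCC(C)CC1CCCCC1`, is not yet measured. It differs from compound 1 by cyclohexyl in place of 4-methylphenyl on a saturated chain carbon, three bonds along the chain from an amide-type nitrogen. Within the data shown here, the one relevant measured step is a 1.4-fold lower number from compound 2 to compound 3 (0.13 log units; within the scatter), an aromatic ring against a saturated chain with no step beyond the scatter. Compound 2, with a saturated chain, also lies within the scatter of compound 1. Neither comparison shows a step beyond the scatter between aromatic and saturated ends. For compound 4 the expected step is therefore a 1.3-fold lower number from compound 1 to compound 4 (0.13 log units; within the scatter), within the scatter. Compound 4 is estimated at 45 nM, between 20 nM and 120 nM.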

Compound 4, half-maximal effective concentration: 17.4 nM
Beside the measured number, compound 4's estimate is 2.6-fold (0.41 log units) above it; measured number outside the range, below it.
By their numbers in this assay, from the lowest: compounds 4, 3, 2 and 1 (each within the scatter of the next, the first and the last beyond it).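

Cyclohexyl in place of 4-methylphenyl gives a step beyond the scatter (a 3.5-fold lower number from compound 1 to compound 4 (0.54 log units; beyond the scatter)), which the earlier aromatic-against-chain pair did not show. The same tail also clears the scatter against the pentyl-ended chain (a 2.2-fold lower number from compound 2 to compound 4 (0.35 log units; beyond the scatter)) but not against the phenyl-ended one (a 1.7-fold lower number from compound 3 to compound 4 (0.22 log units; within the scatter)). Nothing measured here accounts for these steps.

Open, on these data alone, is whether the step belongs to the saturated ring or to the lost methyl, which phenyl or 4-methylcyclohexyl at this place would separate. As far as these compounds go, what a piperidine ring would give here also stays open.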